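The source may report more compounds than this note shows. Statements on the series, on what has been measured and on what is new or still open speak of the compounds shown alone.

In a functional assay on BT-474 cells (Homo sapiens) for inhibition, read by MTT assay, with a stated time of 5 days (on this read-out higher numbers stand for weaker inhibition and lower numbers for stronger inhibition), compound 1 (`Cc1cc(Nc2nc(NCc3ccccc3F)nc3[nH]ncc23)n[nH]1`) gives 13200 nM while compound 2 (`Cc1cc(Nc2nc(NCc3ccccc3Cl)nc3[nH]ncc23)n[nH]1`) gives 7160 nM and compound 3 (`Cc1cc(Nc2nc(NCc3ccc(F)cc3)nc3[nH]ncc23)n[nH]1`) gives 8750 nM so compound 3 stands within the scatter of both others. Compound 4 (`Cc1cc(Nc2nc(NCc3ccc(C#N)cc3)nc3[nH]ncc23)n[nH]1`) has cyano in place of fluoro on an aromatic carbon, para to a large group (cyano in place of fluoro on an aromatic carbon). Among the measured compounds shown here, no measured step makes this exchange. The nearest are chloro in place of fluoro (a 1.8-fold lower number from compound 1 to compound 2 (0.27 log units; within the scatter)) and 4-fluorophenyl in place of 2-chlorophenyl (a 1.2-fold higher number from compound 2 to compound 3 (0.09 log units; within the scatter)), with 4-fluorophenyl in place of 2-fluorophenyl alongside (a 1.5-fold lower number from compound 1 to compound 3 (0.18 log units; within the scatter)), all within the scatter. No step beyond the scatter is therefore expected in this assay and no direction is favoured. The estimated change is a 1.1-fold lower number from compound 3 to compound 4 (0.04 log units; within the scatter) at most a small one. For compound 4 the estimate is 8000 nM within an expected range of 3500 nM to 17000 nM in this series.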

Compound 4, half-maximal inhibitory concentration: 12100 nM
The estimate for compound 4 lay 1.5-fold (0.18 log units) below the measured number; the range from low to high includes it.
By their numbers in this assay, from the lowest: compounds 2, 3, 4 and 1 (each within the scatter of the next).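

In this assay, cyano in place of fluoro on an aromatic carbon, para to a large group, gives a 1.4-fold higher number from compound 3 to compound 4 (0.14 log units; within the scatter) and so adds a hydrogen-bond acceptor at this position with no step beyond the scatter. Set against the ortho-free comparison is not possible in one place alone, but the two wider exchanges read the same way: 4-cyanophenyl in place of 2-chlorophenyl gives a 1.7-fold higher number from compound 2 to compound 4 (0.23 log units; within the scatter) and 4-cyanophenyl in place of 2-fluorophenyl gives a 1.1-fold lower number from compound 1 to compound 4 (0.04 log units; within the scatter). From the compounds shown here alone, whether an amine or a carboxylic acid at this position would give a step beyond the scatter stays open. No measurement shown here bears on the reason for these results.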